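The compounds below may be only part of what the source reports. "The series", "measured", "known", "first", "only" and "open" are said of these compounds alone.

Values in a functional assay on HeLa cells (Homo sapiens) for cytotoxicity, read by resazurin assay, with a stated time of 72 h (a higher number here means a weaker inhibitor, a lower number a stronger inhibitor), so far:
compound 1 `CCSC(=S)SCC(=O)c1ccc(OC)cc1` gives 1960 nM
compound 2 `CCSC(=S)SCC(=O)c1ccc(NS(C)(=O)=O)cc1` gives 45800 nM
compound 3 `CCSC(=S)SCC(=O)c1ccc(CN(C)C(C)=O)cc1` gives 21500 nM

Compound 2 has the highest number of the three, and both other compounds lie beyond the scatter from it. Compound 4 `CCSC(=S)SCC(=O)c1ccc(NC(=O)c2cccnc2)cc1` differs from it thus: (pyridin-3-yl)carbonyl in place of methylsulfonyl on a nitrogen on an aromatic ring with (pyridin-3-yl)carbonyl in place of methylsulfonyl on a nitrogen on an aromatic ring.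

Among the measured compounds shown here, no measured step changes the group on that nitrogen alone. For the measured compounds named here, the closest guide is the modest 2.1-fold lower number from compound 2 to compound 3 (0.33 log units; beyond the scatter) and it is the only step that starts from compound 2. The large steps of a 23-fold higher number from compound 1 to compound 2 (1.37 log units; beyond the scatter) and an 11-fold higher number from compound 1 to compound 3 (1.04 log units; beyond the scatter) both start from methoxy and are a weaker guide here. A modest step to a lower number is therefore expected in this assay for this change. The expected step is a 2.5-fold lower number from compound 2 to compound 4 (0.41 log units; beyond the scatter) on this estimate. For compound 4 the estimated value is 18000 nM with an expected range from 5000 nM to 50000 nM as its upper end.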

Compound 4, half-maximal inhibitory concentration: 5160 nM
Estimate against measurement, compound 4: 3.5-fold (0.54 log units) above; low and high end bracket the measured number.
By their numbers in this assay, from the lowest: compound 1; then compound 4; then compound 3; then compound 2.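

In this assay the group carried by the nitrogen on an aromatic ring matters on its own, with an 8.9-fold lower number from compound 2 to compound 4 (0.95 log units; beyond the scatter) while that nitrogen stays in place. The earlier steps shown here replaced the whole substituent on the aromatic carbon, whereas here (pyridin-3-yl)carbonyl in place of methylsulfonyl gives a lower number. Nothing measured here explains the size of this step.

The compounds shown leave open whether the lower number follows the carbonyl or the pyridine ring. An acetyl or a benzoyl on that nitrogen would separate the two.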